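The compounds below may be only part of what the source reports. "The series", "measured", "known", "first", "only" and "open" are said of these compounds alone.

In an ADME assay on microsomes from liver (Homo sapiens) for metabolic stability (a lower number here means slower removal, a higher number faster removal of the compound), compound 1 (`CC(=O)N[C@@H]1CCC[C@H](C(=O)Nc2cc(-c3cnc(C)n3C(C)C)ccn2)C1`) gives 3.6 mL.min-1.g-1 as a measured number. Compound 2 (`CC(=O)N[C@@H]1CCC[C@H](C(=O)Nc2cc(-c3cnn4c3CCCC4)ccn2)C1`) reports < 3 mL.min-1.g-1 which is a limit of the assay and not a number. Compound 3 (`CC(=O)N[C@@H]1CCC[C@H](C(=O)Nc2cc(-c3cnn4c3CCCC4)c(F)cn2)C1`) reports < 3 mL.min-1.g-1 which is also only a limit. Compound 3 therefore stands at the floor of the read-out, and the limit of < 3 mL.min-1.g-1 in this assay, at which 2 of the 3 values shown sit, includes it.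

Compound 4 (`CC(=O)N[C@@H]1CCC[C@H](C(=O)Nc2cc(-c3cnn4c3CCCC4)c(Cl)cn2)C1`) differs from compound 3 in one place: chloro in place of fluoro on an aromatic carbon.

Going by the values given here, two measured steps bear on this. The closer one is a step that the two limits leave unreadable from compound 2 to compound 3 with fluoro in place of hydrogen on an aromatic carbon, and it gives no usable size. The other is an at least 1.2-fold lower number from compound 1 to compound 2 (0.07 log units; that floor lies within the scatter) and it concerns a different group, so it offers only a weak guide. Among the compounds with values here, no measured step exchanges one halogen for another. The expected step is a number no lower from compound 3 to compound 4 (the limit leaves the size open) and no move beyond the scatter is expected in this assay in either direction.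

Compound 4 is estimated at 3 mL.min-1.g-1 with an expected range from 2 mL.min-1.g-1 to 6 mL.min-1.g-1 and a report of only a limit is the more likely outcome.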

Compound 4, intrinsic clearance in microsomes: 17 mL.min-1.g-1
For compound 4 the middle estimate is 5.7-fold (0.75 log units) below the measured one, and the stated range ends below it.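

In this assay this position, on an aromatic carbon two atoms from the ring nitrogen, does not treat the two halogens alike: chloro in place of fluoro gives a clear rise (an at least 5.6-fold higher number from compound 3 to compound 4 (0.75 log units; beyond the scatter)). Chloro in place of hydrogen gives a rise of the same printed size (an at least 5.6-fold higher number from compound 2 to compound 4 (0.75 log units; beyond the scatter)), so the higher number goes with chloro whichever of the two compounds serves as the reference. Going by these compounds alone, both steps start from a limit and not from a number, so their true sizes may be larger, and until this result the compounds with the group of 9 heavy atoms showed only the floor of the read-out: the limit of < 3 mL.min-1.g-1 in this assay, at which 2 of the 4 values shown sit.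

The step from compound 2 to compound 3 cannot be read, as both ends are limits, so fluoro against hydrogen stays undecided at this position. Also open, from the compounds shown here alone, are how bromo, methyl, methoxy or a nitrile would read at the same carbon, and whether chloro would raise the number in the same way on the core of compound 1.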